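The compounds below may be only part of what the source reports. "The series", "measured", "known", "first", "only" and "open" are said of these compounds alone.

Working notes on the series. The shared core carries a ring amine nitrogen whose substituent is varied. Compound 1 `NCCNc1cc(N2CCN(S(=O)(=O)c3ccccc3)CC2)nc2ccccc12` carries a phenylsulfonyl there, and in an ADME assay on HEp-2 cells (Homo sapiens) for cytotoxicity, read by CCK-8 assay, with a stated time of 6 days (a higher number here means that more compound is tolerated, a lower number that less compound is tolerated), compound 1 gives 20500 nM. Compound 2 `NCCNc1cc(N2CCN(C(=O)C3(c4ccccc4)CCCC3)CC2)nc2ccccc12` carries a 1-phenylcyclopentylcarbonyl on that nitrogen. For compound 2 this assay reports only a limit, > 100000 nM. Compound 3 `CC(C)CC(=O)N1CCN(c2cc(NCCN)c3ccccc3n2)CC1` carries an isobutylcarbonyl on that nitrogen. For compound 3 this assay again reports only a limit, > 100000 nM. Among the measured compounds shown here, compound 1 is thus the one compound with a measured number, while the other two sit at the limit of > 100000 nM in this assay, at which 2 of the 3 values shown sit.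

Compound 4 `CS(=O)(=O)N1CCN(c2cc(NCCN)c3ccccc3n2)CC1` differs from compound 1 by methyl in place of phenyl on a sulfonyl sulfur. Of the measured steps, the one that bears on this change is an at least 4.8-fold higher number from compound 1 to compound 3 (0.68 log units; beyond the scatter), which also removes the phenylsulfonyl from compound 1 and lands at the limit. The other step, a step that the two limits leave unreadable from compound 2 to compound 3, gives no readable size. Compound 4 keeps the sulfonyl and removes only the phenyl, so a smaller move in the same upward direction is expected, read against an at least 4.8-fold higher number from compound 1 to compound 3 (0.68 log units; beyond the scatter), with the limit within reach.

The expected step is a 2.4-fold higher number from compound 1 to compound 4 (0.39 log units; beyond the scatter). Compound 4 is estimated at 50000 nM, with a range from 15000 nM to 150000 nM.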

Compound 4, half-maximal cytotoxic concentration: > 100000 nM
Compound 4 ended at the assay's limit; the forecaster's own chance of this, stated with the estimate: 40%; at least 2.0-fold (0.30 log units) between middle value and limit.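

Methyl in place of phenyl on the sulfonyl sulfur gives an at least 4.8-fold higher number from compound 1 to compound 4 (0.68 log units; beyond the scatter), so the sulfonyl can stay and the number in this assay still reaches the limit; the earlier step from compound 1 changed the sulfonyl and the phenyl together. The phenyl goes with the lower number only on the sulfonyl sulfur, and compound 2 goes against any wider reading: it holds a phenyl within its 1-phenylcyclopentylcarbonyl, yet its value is only a limit, > 100000 nM. The step between compound 3 and compound 4 cannot be read, and this end of the series no longer separates its members: the limit of > 100000 nM in this assay, at which 3 of the 4 values shown sit.

How much of the phenyl is needed for a measured number stays open, since the compounds shown hold nothing on the sulfonyl sulfur between methyl and phenyl, such as an ethyl, a cyclopropyl or a benzyl. Also open, on these data alone, is whether a phenyl carrying a chlorine, an amine or a carboxylic acid on that sulfonyl would stay near compound 1 or move to the limit.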